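A few compounds are considered here, and "the series" means these few. Any claim that something is new, unique, unknown or untested is made for them only; others in the source may bear on it.

Measured in an assay on isolated protein for inhibition of bone morphogenetic protein 1 (Homo sapiens); a higher number here means a weaker inhibitor, a lower number a stronger inhibitor:
compound 1 `COc1ccc(S(=O)(=O)N(Cc2cccc(Br)c2)[C@H](C)C(=O)NO)cc1`: 93 nM
compound 2 `COc1ccc(S(=O)(=O)N(Cc2ccccc2C(F)(F)F)[C@H](C)C(=O)NO)cc1`: 6 nM

Of these two numbers, compound 1 has the higher one in this assay, and compound 2 the lower; the gap between them lies beyond the usual scatter, so compound 1 is the weaker inhibitor of the pair. Compound 3 `COc1ccc(S(=O)(=O)N(Cc2cc(F)cc(F)c2)[C@H](C)C(=O)NO)cc1` has not yet been measured. It differs from compound 1 in a single place: 3,5-difluorophenyl in place of 3-bromophenyl on a saturated chain carbon bound to a sulfonamide nitrogen. Among the measured compounds shown here, both groups are halogen-bearing rings on the same chain carbon next to the sulfonamide nitrogen, and no measured pair here isolates a change of this kind, so there is no directly comparable step to lean on. A modest step, if any, is expected from compound 1 to compound 3, as a 1.3-fold higher number from compound 1 to compound 3 (0.11 log units; within the scatter), with a wide range. For compound 3 the estimated value in this assay is 120 nM, between 40 nM and 350 nM.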

Compound 3, half-maximal inhibitory concentration: 140 nM
For compound 3 the middle estimate is 1.2-fold (0.07 log units) below the measured one; measured number inside the range.
By their numbers in this assay, from the lowest: compound 2; then compounds 1 and 3 (each within the scatter of the next).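

In this assay, the change from 3-bromophenyl to 3,5-difluorophenyl on a saturated chain carbon bound to a sulfonamide nitrogen gives a small step (a 1.5-fold higher number from compound 1 to compound 3 (0.18 log units; within the scatter)). Among the compounds shown here, this is the first direct comparison of two rings at this place, and it shows that one bromine can give way to two fluorines with no change that stands out from the scatter. No measurement at hand offers an explanation for this result.

On these data alone, whether a halogen on this ring matters at all stays open, and a plain phenyl, or a phenyl ring carrying an amine or a carboxylic acid instead, would speak to that. A ring with a single fluorine would also show whether one fluorine gives a number like that of the two.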